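This account rests on a few compounds, and the source may have more. Where it says the series, first, only, none or still open, it means among the compounds named here.

Measured in a functional assay on KB cells (Homo sapiens) for antiproliferative activity, read by sulforhodamine B assay, with a stated time of 3 days; on this read-out lower numbers stand for an effect already at smaller amounts and higher numbers for an effect only at larger amounts of compound:
- compound 1 `CCC1=C(O)c2c(oc(-c3ccc(O)c(O)c3)cc2=O)C(CC)(CC)C1=O`: 10 uM
- compound 2 `CCC1=C(O)c2c(oc(-c3cc(C)ccc3C)cc2=O)C(CC)(CC)C1=O`: 14.5 uM
- compound 3 `CCC1=C(O)c2c(oc(-c3cc(C)ccc3F)cc2=O)C(CC)(CC)C1=O`: 47.3 uM

Compound 3 has the highest number of the three. Compound 4 `CCC1=C(O)c2c(oc(-c3ccc(F)c(C)c3)cc2=O)C(CC)(CC)C1=O` has the same atoms joined differently, with 4-fluoro-3-methylphenyl in place of 2-fluoro-5-methylphenyl on an aromatic carbon. Among the compounds with values here, no measured step rearranges these groups in this way. The closest evidence is fluoro in place of methyl, a 3.3-fold higher number from compound 2 to compound 3 (0.51 log units; beyond the scatter), and a change of the whole phenyl group, a 4.7-fold higher number from compound 1 to compound 3 (0.67 log units; beyond the scatter), both modest, while a 1.5-fold higher number from compound 1 to compound 2 (0.16 log units; within the scatter) stays within the scatter. With compound 3 at 47.3 uM, the top of this small spread, a modest move towards lower numbers is expected. The expected step is a 2.2-fold lower number from compound 3 to compound 4 (0.33 log units; beyond the scatter). For compound 4 the estimate is 22 uM, with an expected range of 9 uM to 50 uM.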

Compound 4, concentration for half-maximal effect: 40.5 uM
Compound 4: the middle estimate sits 1.8-fold (0.27 log units) below what was measured, and the stated range covers the measured number.
By their numbers in this assay, from the lowest: compounds 1 and 2 (each within the scatter of the next); then compounds 4 and 3 (each within the scatter of the next).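

In this assay, the 4-fluoro-3-methylphenyl group in place of the 2-fluoro-5-methylphenyl group gives a 1.2-fold lower number from compound 3 to compound 4 (0.07 log units; within the scatter) and so, on this aromatic carbon, rearranging the same atoms makes no difference that stands out from the scatter. Compound 4 stays apart from the two compounds without fluoro, with a 2.8-fold higher number from compound 2 to compound 4 (0.45 log units; beyond the scatter) and a 4.1-fold higher number from compound 1 to compound 4 (0.61 log units; beyond the scatter) in this small set. No other measurement is at hand to explain these numbers.

From the compounds shown here alone, what an amine or a carboxylic acid on this phenyl ring would do stays open. So does whether a phenyl ring carrying fluoro without any methyl would give similar numbers.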